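A Methoxy Added to the Benzyl Group of Compound 2

This account rests on a few compounds, and the source may have more. Where it says the series, first, only, none or still open, it means among the compounds named here.

Of the compounds shown here, two with a shared core have been measured so far. Compound 1 `COc1ccc(NC(=O)c2cc(Oc3ccc(/C=C/c4ccccn4)cc3)ccn2)cc1` carries a 4-methoxyphenyl group on its amide nitrogen, and in a functional assay on HepG2 cells (Homo sapiens) for antiproliferative activity, read by CCK-8 assay, with a stated time of 48 h (on this read-out higher numbers stand for weaker inhibition and lower numbers for stronger inhibition), compound 1 gives 30000 nM. Compound 2 `O=C(NCc1ccccc1)c1cc(Oc2ccc(/C=C/c3ccccn3)cc2)ccn1` carries a benzyl group in that position instead, and in this assay compound 2 gives 27900 nM. Going by the values given here, the only step known is a 1.1-fold lower number from compound 1 to compound 2 (0.03 log units; within the scatter), so the two values cannot be told apart, and compound 2 is simply one of two compounds that sit at the same level.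

Compound 3 `COc1ccc(CNC(=O)c2cc(Oc3ccc(/C=C/c4ccccn4)cc3)ccn2)cc1` is the next compound. It differs from compound 2 in one place: methoxy in place of hydrogen on an aromatic carbon. The methoxy group enters on an aromatic carbon of the six-membered ring of the benzyl group, para to a large group.

Among the compounds with values here, the one step that bears on this change is the one from compound 1 to compound 2, which swapped a 4-methoxyphenyl for a benzyl and stayed within the scatter. A methoxy group was therefore present on compound 1 without setting its number apart. On that basis, compound 3 is expected to stay close to compound 2, with a step of a 1.0-fold higher number from compound 2 to compound 3 (0.00 log units; within the scatter) in this assay, within the scatter. For compound 3 the estimate is 28000 nM, with a range from 12000 nM to 65000 nM.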

Compound 3, half-maximal inhibitory concentration: 26000 nM
Beside the measured number, compound 3's estimate is 1.1-fold (0.03 log units) above it; the measured number falls inside the stated range.
By their numbers in this assay, from the lowest: compounds 3, 2 and 1 (each within the scatter of the next).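

In this assay, going by these compounds alone, placing a methoxy group on the aromatic carbon of the benzyl ring, para to a large group, gives a 1.1-fold lower number from compound 2 to compound 3 (0.03 log units; within the scatter) and so leaves compound 2 and compound 3 indistinguishable, which is the first direct test of this group on this ring. The second comparison holds a methoxy group on the ring in both compounds and swaps 4-methoxyphenyl for 4-methoxybenzyl on the amide nitrogen, giving a 1.2-fold lower number from compound 1 to compound 3 (0.06 log units; within the scatter) as another step that cannot be told apart from repeat-measurement noise. All three compounds therefore sit at one level on this read-out, and no further measurement is available to account for that.

The compounds shown leave open whether an amine or a carboxylic acid on that same ring carbon, or a longer chain such as butoxy in place of the methoxy group, would move the number away from this level. They also leave open whether a methoxy group on a different carbon of the benzyl ring would give a value that can be told apart from that of compound 2.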